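The source may report more compounds than this note shows. Statements on the series, on what has been measured and on what is new or still open speak of the compounds shown alone.

Values in a functional assay on Shh Light II cells (Mus musculus) for inhibition, read by a luciferase reporter (a higher number here means a weaker inhibitor, a lower number a stronger inhibitor), are as follows
compound 1 `CC(C)c1ccccc1NC(=O)N1CCC(c2nc(-c3ccc4ccccc4n3)no2)CC1` gives 480 nM
compound 2 `O=C(Nc1cccc2cccnc12)N1CCC(c2nc(-c3ccc4ccccc4n3)no2)CC1` gives 1400 nM
compound 3 `COc1ccccc1NC(=O)N1CCC(c2nc(-c3ccc4ccccc4n3)no2)CC1` gives 410 nM

Compound 3 shares the low end of these numbers with compound 1, while the gap to the remaining compound is clear (a 3.4-fold lower number from compound 2 to compound 3 (0.53 log units; beyond the scatter)). The untested compound 4 `Cc1ccccc1NC(=O)N1CCC(c2nc(-c3ccc4ccccc4n3)no2)CC1` carries methyl in place of methoxy on an aromatic carbon, ortho to a large group (methyl in place of methoxy on an aromatic carbon). The closest measured guide is the swap at that same place between isopropyl and methoxy, which moved the number little (a 1.2-fold lower number from compound 1 to compound 3 (0.07 log units; within the scatter)). The steps involving compound 2 replace a whole aromatic group, so they bear less on this change. For compound 4 the expected outcome is a 1.1-fold higher number from compound 3 to compound 4 (0.04 log units; within the scatter) and so no step beyond the scatter. Compound 4 is estimated at 450 nM in this assay, with 220 nM to 900 nM as the expected range.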

Compound 4, half-maximal inhibitory concentration: 440 nM
Compound 4: middle estimate off by 1.0-fold (0.01 log units), on the high side, and the stated range covers the measured number.
By their numbers in this assay, from the lowest: compounds 3, 4 and 1 (each within the scatter of the next); then compound 2.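

Replacing methoxy with methyl removes the oxygen and its hydrogen-bond acceptor, yet the result stays within the scatter (a 1.1-fold higher number from compound 3 to compound 4 (0.03 log units; within the scatter)), as does the swap of isopropyl for methyl (a 1.1-fold lower number from compound 1 to compound 4 (0.04 log units; within the scatter)), so methoxy, methyl and isopropyl cannot be told apart at this aromatic carbon. The step from the quinolin-8-yl group remains clear (a 3.2-fold lower number from compound 2 to compound 4 (0.50 log units; beyond the scatter)). No measurement at hand explains these results.

Still open, going by these compounds, is whether a chlorine atom, a hydroxyl or a dimethylamino group on this same aromatic carbon would keep the number in this range.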